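The compounds below may be only part of what the source reports. "The series", "measured", "known", "first", "only" and "open" are said of these compounds alone.

Compound 1 `COc1cccc(N2C(=O)COc3ccc(-c4cnc(Cl)c(NS(=O)(=O)c5ccc(F)cc5)c4)cc32)c1`: > 40000 nM.
Compound 2 `O=C1COc2ccc(-c3cccc(NS(=O)(=O)c4ccc(F)cc4)c3)cc2N1`: > 40000 nM.
Compound 3 `COc1cccc(N2C(=O)COc3ccc(-c4cnc(OC)c(NS(=O)(=O)c5ccc(F)cc5)c4)cc32)c1`: > 40000 nM.

All three entries come from a functional assay on HCT-116 cells (Homo sapiens) for antiproliferative activity, read by MTT assay, with a stated time of 72 h (on this read-out lower numbers stand for stronger inhibition and higher numbers for weaker inhibition), and each is a limit of the assay, not a number. Compound 1 therefore offers no number to step from, and it sits with the others at the limit of > 40000 nM in this assay, at which 3 of the 3 values shown sit.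

Compound 4 `CC(C)N1C(=O)COc2ccc(-c3cnc(Cl)c(NS(=O)(=O)c4ccc(F)cc4)c3)cc21` keeps the core of compound 1 and changes one group: isopropyl in place of 3-methoxyphenyl on an amide-type nitrogen in a ring. In words, this is isopropyl in place of 3-methoxyphenyl on an amide-type nitrogen in a ring.

Among the compounds with values here, the only measured step is a step that the two limits leave unreadable from compound 1 to compound 3. It concerns methoxy in place of chloro, a different change, and it gives no size to carry over. Compound 2 has the amide hydrogen on that nitrogen but differs elsewhere as well, and its > 40000 nM is again a limit.

Within the data shown here, no measured step therefore bears directly on this change. The expectation for compound 4 rests only on compound 1 and its limit of > 40000 nM. Compound 4 is expected to stay weak in this assay, most likely again reported as a limit, with some chance of a move toward stronger inhibition. The estimated step is an at least 1.6-fold lower number from compound 1 to compound 4 (0.20 log units; that floor lies within the scatter). For compound 4 the estimated value is 25000 nM, with an expected range of 3000 nM to 80000 nM.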

Compound 4, half-maximal inhibitory concentration: 18900 nM
Compound 4: the middle estimate sits 1.3-fold (0.12 log units) above what was measured; low and high end bracket the measured number.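

In this assay, within the data shown here, isopropyl in place of 3-methoxyphenyl on the amide-type nitrogen gives the first readable number, with an at least 2.1-fold lower number from compound 1 to compound 4 (0.32 log units; beyond the scatter). Among these compounds, this shows that the read-out at this position can respond to the group carried there, which the earlier compounds could not show, and the step is a floor, so its full size stays unknown. Compound 1, compound 2 and compound 3 remain limits and not numbers: the limit of > 40000 nM in this assay, at which 3 of the 4 values shown sit.

A single pair does not separate the loss of the aromatic ring from the smaller group, and a cyclopropyl group, a longer alkyl chain or a chain ending in an amine on that nitrogen would bear on this question. On these data alone, it also remains open whether the isopropyl change would produce a readable number with methoxy in place of chloro on the shared core, and whether any group at this position can bring the number far below that of compound 4, 18900 nM.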